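Amide side-chain swap and cell tolerance in the core series

The source may hold more compounds than are shown below. What is called first, only, known or untested is meant among the compounds shown, and "the series" means these compounds.

compound 1 `COc1ccc(-c2cnc(NC(=O)CCc3ccccc3)n2C)cc1`: > 100000 nM
compound 2 `O=C(Nc1ncc(-c2ccccc2)o1)c1ccc(F)cc1`: 17000 nM

In a toxicity assay on THP-1 cells (Homo sapiens) for inhibition (a lower number here means that less compound is tolerated, a higher number that more compound is tolerated), compound 1 gives > 100000 nM; this is a limit of the assay, not a number (the limit of > 100000 nM in this assay, at which 1 of the 2 values shown sits). Among the measured compounds shown here, no single-place step links compound 1 to compound 2; in this assay compound 2 gives 17000 nM.

Compound 3 `COc1ccc(-c2cnc(NC(=O)c3ccc(C)cc3)n2C)cc1` differs from compound 1 by 4-methylphenyl in place of phenethyl on a carbonyl carbon. For the measured compounds named here, no measured step covers this change, so the expected step of a number no higher from compound 1 to compound 3 (the limit leaves the size open) is none beyond the scatter. Compound 3 is therefore estimated at 100000 nM in this assay, with a range from 30000 nM to 300000 nM, and a limit is again likely.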

Compound 3, half-maximal cytotoxic concentration: > 100000 nM
Compound 3: only a limit was reported; the forecaster's own chance of this, stated with the estimate: 65%; the middle value sits exactly at the limit.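

No new step can be read between compound 1 and compound 3, since both stand as limits of the assay, not numbers: the limit of > 100000 nM in this assay, at which 2 of the 3 values shown sit.
On these data alone, whether 4-methylphenyl in place of phenethyl on a carbonyl carbon shifts the result in this assay stays open, as does any single-place link to compound 2.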